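Series notes: aryl variation and kinase kinase 4 binding

A few compounds are considered here, and "the series" means these few. Any claim that something is new, unique, unknown or untested is made for them only; others in the source may bear on it.

compound 1 `CCCS(=O)(=O)Nc1ccc(F)c(C(=O)c2n[nH]c3ncc(-c4cccc(C)c4)cc23)c1F` — 15%
compound 2 `CCCS(=O)(=O)Nc1ccc(F)c(C(=O)c2n[nH]c3ncc(-c4cccc(N(C)C)c4)cc23)c1F` — 26%
compound 3 `CCCS(=O)(=O)Nc1ccc(F)c(C(=O)c2n[nH]c3ncc(-c4ccc(C(C)(C)C)cc4)cc23)c1F` — 46%

In an assay for binding affinity to dual specificity mitogen-activated protein kinase kinase 4 (Homo sapiens), read by KINOMEscan, tested at 100 nM (a higher number here means a weaker effect of the compound at the concentration tested, a lower number a stronger effect), compound 2 gives 26%, the second highest of the three numbers: compound 1 lies lower, a number 11 percentage points higher from compound 1 to compound 2 (beyond the scatter), and compound 3 lies higher, a number 20 percentage points higher from compound 2 to compound 3 (beyond the scatter). Compound 4 `CCCS(=O)(=O)Nc1ccc(F)c(C(=O)c2n[nH]c3ncc(-c4ccc(S(=O)(=O)NCC)cc4)cc23)c1F` is not yet measured. Its change from compound 2: 4-(ethylsulfamoyl)phenyl in place of 3-(dimethylamino)phenyl on an aromatic carbon. Going by the values given here, the steps that bear on it are a number 20 percentage points higher from compound 2 to compound 3 (beyond the scatter) and a number 31 percentage points higher from compound 1 to compound 3 (beyond the scatter), both ending at 4-(tert-butyl)phenyl and both raising the number beyond the scatter. The entering 4-(ethylsulfamoyl)phenyl is larger still, so a modest rise is expected, a number 16 percentage points higher from compound 2 to compound 4 (beyond the scatter). Compound 4 is estimated at 42%, with a range from 22% to 65%.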

Compound 4, a percentage reported as activity, at one concentration (the size of the read-out at that concentration, not a potency): 3%
Beside the measured number, compound 4's estimate is 39 percentage points above it; measured number below the stated range.
By their numbers in this assay, from the lowest: compound 4; then compound 1; then compound 2; then compound 3.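

In this assay a larger group at this position does not have to raise the number: with 12 heavy atoms entering for 9, the change gives a number 23 percentage points lower from compound 2 to compound 4 (beyond the scatter) and, against 3-methylphenyl, a number 12 percentage points lower from compound 1 to compound 4 (beyond the scatter) as the first step from compound 1 to go down. With the 4-substituted phenyl kept, ethylsulfamoyl in place of tert-butyl gives a number 43 percentage points lower from compound 3 to compound 4 (beyond the scatter) and so separates two groups at the same ring position. Nothing available here bears on the reason for this result.

Open, going by these compounds, is whether the number follows the sulfamoyl amine hydrogen or the ethyl chain. A methylsulfonyl group or an unsubstituted sulfamoyl in place of ethylsulfamoyl would separate the two.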